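Removing the butyl chain from compound 3

The source may report more compounds than this note shows. Statements on the series, on what has been measured and on what is new or still open speak of the compounds shown alone.

- Compound 1 `C/C(=N\C#N)N(Cc1ccccc1)Cc1ccc(Cl)nc1` gives 2.11
- Compound 2 `CCC/C(=N\C#N)N(C)Cc1ccc(Cl)nc1` gives 1.55
- Compound 3 `CCCCN(Cc1ccc(Cl)nc1)/C(C)=N/C#N` gives 2.13

In a physicochemical assay for lipophilicity, read by HPLC, using the shake flask method (on this read-out lower numbers stand for lower lipophilicity and higher numbers for higher lipophilicity), compound 3 stands at 2.13, level with compound 1 within the scatter and beyond the scatter above compound 2. The next case is compound 4 `C/C(=N\C#N)NCc1ccc(Cl)nc1`. The change is hydrogen in place of butyl on an amine nitrogen.

Going by the values given here, only one measured step bears on this chain: a number 0.02 log units higher from compound 1 to compound 3 (within the scatter). That step swaps one group for another and leaves a carbon chain on the nitrogen, so it is a weak guide. Among the compounds with values here, no measured compound has hydrogen there, which makes this an extrapolation. Within the data shown here, compound 2 differs from compound 3 in more than one place, so it offers no clean step. Even so, a fall is expected that is larger than the gap separating compound 3 from compound 2. Compound 2 gives 1.55. The expected size is a number 1.33 log units lower from compound 3 to compound 4 (beyond the scatter). For compound 4 the estimate is 0.8, with an expected range from 0.4 to 1.2.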

Compound 4, partition coefficient: 1.07
Compound 4: middle estimate off by 0.27 log units, on the low side; the measured number falls inside the stated range.
By their numbers in this assay, from the lowest: compound 4; then compound 2; then compounds 1 and 3 (each within the scatter of the next).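

Going by these compounds alone, compound 4 is the first case here with hydrogen on the amine nitrogen, and in this assay removing the butyl chain gives a number 1.06 log units lower from compound 3 to compound 4 (beyond the scatter). Removing the benzyl group instead gives a number 1.04 log units lower from compound 1 to compound 4 (beyond the scatter), so both carbon groups, very different in shape, stand well above hydrogen at this place, while exchanging one for the other gave only a number 0.02 log units higher from compound 1 to compound 3 (within the scatter). No measurement here explains the size of these steps.

Still open, as far as these compounds go, is how the number moves between hydrogen and butyl: an ethyl group on this nitrogen, with the rest of compound 4 unchanged, would show whether the climb is gradual. A longer chain, such as hexyl, would show whether the number keeps moving beyond butyl at this place.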